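Swapping the Side Ring on a Kinase Inhibitor Core

This account rests on a few compounds, and the source may have more. Where it says the series, first, only, none or still open, it means among the compounds named here.

Of the compounds shown here, three sharing one core have been tested in an assay on isolated protein for inhibition of G protein-coupled receptor kinase 6 (Homo sapiens), read by scintillation counting, radiometric assay and 33P incorporation, with a stated time of 80 min, in the presence of a further agent that is not named here; a lower number here means a stronger inhibitor, a higher number a weaker inhibitor. Compound 1 `CCc1cc(Nc2nc(N[C@@H](C)c3ccc(F)cn3)nc3cccc(F)c23)n[nH]1` gives 29 nM. Compound 2 `CCc1cc(Nc2nc(N[C@@H](C)c3ccc(C)cc3)nc3cccc(F)c23)n[nH]1` gives 27 nM. Compound 3 `CCc1cc(Nc2nc(N[C@@H](C)c3ccc(F)cc3)nc3cccc(F)c23)n[nH]1` gives 41 nM. Among these three numbers compound 3 has the highest, but all the gaps are small: a 1.1-fold lower number from compound 1 to compound 2 (0.03 log units; within the scatter), a 1.5-fold higher number from compound 2 to compound 3 (0.18 log units; within the scatter). Among the measured compounds shown here, on these data no compound can be called stronger or weaker than another.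

Compound 4 `CCc1cc(Nc2nc(N[C@@H](C)c3ccc(C#N)cn3)nc3cccc(F)c23)n[nH]1` has not yet been measured. It differs from compound 3 in one place: 5-cyanopyridin-2-yl in place of 4-fluorophenyl on a saturated chain carbon bound to a nitrogen on an aromatic ring and a saturated chain carbon. The step that bears most directly on this change is the one in which a pyridyl ring on that same saturated chain carbon was replaced by a phenyl ring, a 1.4-fold higher number from compound 1 to compound 3 (0.15 log units; within the scatter). That exchange of a ring with one hetero atom for a ring of carbon only left the number essentially unchanged, and the methyl-for-fluoro exchange on the ring carbon did likewise. Because the pyridyl-to-phenyl step a 1.4-fold higher number from compound 1 to compound 3 (0.15 log units; within the scatter) stayed within the scatter, returning to a pyridyl ring, now carrying a nitrile, is expected to shift the number little, if at all, in either direction. Compound 4 is therefore expected to give about 30 nM, with a range from 12 nM to 80 nM, which would mean a 1.4-fold lower number from compound 3 to compound 4 (0.14 log units; within the scatter).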

Compound 4, half-maximal inhibitory concentration: 91 nM
Compound 4: the middle estimate sits 3.0-fold (0.48 log units) below what was measured; measured number outside the range, above it.
By their numbers in this assay, from the lowest: compounds 2, 1 and 3 (each within the scatter of the next); then compound 4.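

Up to compound 3, every exchange on this saturated chain carbon stayed within the scatter, so the position looked indifferent to which ring it carried. In this assay, among the compounds shown here, the 5-cyanopyridin-2-yl group gives the first steps beyond the scatter, both modest, when it replaces 4-fluorophenyl (a 2.2-fold higher number from compound 3 to compound 4 (0.35 log units; beyond the scatter)) or 4-methylphenyl (a 3.4-fold higher number from compound 2 to compound 4 (0.53 log units; beyond the scatter)). The cleanest comparison keeps the ring type and exchanges only the group on it, cyano in place of fluoro on an aromatic carbon (a 3.1-fold higher number from compound 1 to compound 4 (0.50 log units; beyond the scatter)), so among these four compounds the higher number goes with the nitrile and not with the pyridyl ring as such, although no measurement here shows what lies behind that step.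

A 4-cyanophenyl group would show whether the nitrile raises the number on a carbon-only ring too, or only on the pyridyl ring of compound 4. A 5-methylpyridin-2-yl or 5-methoxypyridin-2-yl group would show whether fluoro is one of several groups that this ring accepts, or whether the nitrile alone stands apart.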